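A few compounds are considered here, and "the series" means these few. Any claim that something is new, unique, unknown or untested is made for them only; others in the source may bear on it.

Compound 1 `COc1cc(C[C@H]2C(=O)OC[C@@H]2Cc2ccc(OC)c(OC)c2)ccc1NC(C)=O`: > 50000 nM, a limit
Compound 2 `COc1cc(C[C@H]2C(=O)OC[C@@H]2Cc2ccc(OC)c(OC)c2)ccc1NCc1ccccc1`: > 50000 nM, a limit

In an ADME assay on A549 cells (Homo sapiens) for cytotoxicity, read by MTT assay, with a stated time of 4 days (on this read-out lower numbers stand for stronger inhibition and higher numbers for weaker inhibition), compound 2 gives only a limit, > 50000 nM. Going by the values given here, nothing firmer is available, as the whole series so far stands at the limit of > 50000 nM in this assay, at which 2 of the 2 values shown sit. Compound 3 `COc1cccc(C[C@H]2C(=O)OC[C@@H]2Cc2ccc(OC)c(OC)c2)c1` follows from compound 2 by hydrogen in place of benzylamino on an aromatic carbon. Among the compounds with values here, the one measured step bearing on this, a step that the two limits leave unreadable from compound 1 to compound 2, offers no size to carry over. No change beyond the scatter is therefore expected, in either direction, and another limit is likely. The expected size is a step that the limit leaves unreadable from compound 2 to compound 3. For compound 3 the estimate is 60000 nM, with an expected range of 25000 nM to 120000 nM.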

Compound 3, half-maximal inhibitory concentration: > 50000 nM
Compound 3 gave a limit, no number; the forecaster's own chance of this, stated with the estimate: 80%; the middle value lies beyond the limit too.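

No step can be read among compound 1, compound 2 and compound 3, as each gives only a limit in this assay: the limit of > 50000 nM in this assay, at which 3 of the 3 values shown sit. As far as these compounds go, whether any change to the shared core gives a measurable value in this assay stays open.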